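A few compounds are considered here, and "the series" means these few. Any claim that something is new, unique, unknown or untested is made for them only; others in the source may bear on it.

Compound 1 `COc1ccc(-c2[nH]c3ccccc3c2/C=C(\C#N)S(=O)(=O)c2ccccc2)cc1` is the reference point of this small set. In a functional assay on A549 cells (Homo sapiens) for inhibition, read by sulforhodamine B assay, with a stated time of 48 h (on this read-out higher numbers stand for weaker inhibition of growth and lower numbers for stronger inhibition of growth), compound 1 gives 803 nM, the lowest of the three numbers measured. Compound 3 `COc1ccc(-c2[nH]c3ccc(OC)cc3c2/C=C(\C#N)S(=O)(=O)c2ccccc2)cc1`, which carries an additional methoxy on the shared core, gives 2800 nM in this assay. Compound 2 `COc1ccc2[nH]c(-c3ccccc3)c(C=C(C#N)C#N)c2c1` differs from compound 1 in several places; in this assay compound 2 gives 7000 nM. For the measured compounds named here, the one single-point step available is a 3.5-fold higher number from compound 1 to compound 3 (0.54 log units; beyond the scatter), a methoxy in place of hydrogen on an aromatic carbon.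

Compound 4 `N#C/C(=C\c1c(-c2ccccc2)[nH]c2ccccc12)S(=O)(=O)c1ccccc1` is compound 1 with hydrogen in place of methoxy on an aromatic carbon, which leaves the core itself unchanged. The step from compound 1 to compound 3 shows that a methoxy change elsewhere on the scaffold moved the number by a modest amount, so a change of similar size is plausible here, though the direction of removing a methoxy from a different ring is not fixed by the data. Compound 4 is therefore expected to give 1200 nM, within 400 nM to 3600 nM, which would mean an expected step of a 1.5-fold higher number from compound 1 to compound 4 (0.17 log units; within the scatter).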

Compound 4, concentration for 50% growth inhibition: 3700 nM
Beside the measured number, compound 4's estimate is 3.1-fold (0.49 log units) below it; measured number above the stated range.
By their numbers in this assay, from the lowest: compound 1; then compounds 3, 4 and 2 (each within the scatter of the next, the first and the last beyond it).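

In this assay, the change from 4-methoxyphenyl to phenyl gives a 4.6-fold higher number from compound 1 to compound 4 (0.66 log units; beyond the scatter) and so weakens growth inhibition, which shows that the methoxy at this position counts on this read-out. The earlier compounds shown here showed only the effect of adding a methoxy to the shared core, a 3.5-fold higher number from compound 1 to compound 3 (0.54 log units; beyond the scatter) and also a weakening, so compound 1 now loses ground both when a methoxy is added at that place and when this one is removed. Nothing available gives a reason for this shift in the number.

The compounds shown leave open whether a hydroxyl, an amine or an ethoxy group at this position would hold the number of compound 1 or lower it. They also leave open whether the change from 4-methoxyphenyl to phenyl has the same effect on the core of compound 3.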